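The compounds below may be only part of what the source reports. "The series", "measured", "known", "first", "only" and "open" are said of these compounds alone.

Measured in an ADME assay on a cell-free system (plasma, Rattus norvegicus) for metabolic stability, read by LC-MS, with a stated time of 1 h, at 37 degrees C, tested at 100 uM; a lower number here means that less of the compound is left, a higher number that more of the compound is left:
compound 1 `Cn1sc2cc(OCc3cccc(-c4ccc(Cl)c(C(=O)O)c4)c3)ccc2c1=O` gives 100%
compound 2 `O=C1c2ccc(OCc3cccc(-c4ccccc4)c3)cc2CN1C1CCCC1` gives 95%
compound 3 `O=C1c2ccc(OCc3cccc(-c4ccc(C(F)(F)F)cc4F)c3)cc2CN1C1CCCC1` gives "not determined" (no result reported)

Compound 1 gives 100% and compound 2 gives 95%, two values within the usual scatter of each other. Compound 3 adds no number to compare. Among the compounds with values here, compound 1 therefore stands level with the only other measured compound, and both show the compound essentially still present at the end of the test.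

Compound 4 `O=C(O)c1cc(-c2cccc(COc3ccc4c(=O)n(C5CCC5)sc4c3)c2)ccc1Cl` keeps the core of compound 1 and changes one group, on an aromatic nitrogen next to the ring sulfur: cyclobutyl in place of methyl on an aromatic nitrogen. Within the data shown here, no measured pair shows what such a swap does here, so the expectation rests on a single comparison. Compound 2, which also carries a ring of carbon only on a nitrogen, gives 95%, although its core differs. The expected step is a number 4 percentage points lower from compound 1 to compound 4 (within the scatter), which would be no change beyond the scatter. For compound 4 the estimated value is 96%, with an expected range from 84% to 100%.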

Compound 4, percent of the compound remaining: 91%
For compound 4 the middle estimate is 5 percentage points above the measured one; the measured number falls inside the stated range.
By their numbers in this assay, from the lowest: compounds 4, 2 and 1 (each within the scatter of the next).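

In this assay cyclobutyl in place of methyl on an aromatic nitrogen, next to the ring sulfur, can now be read on its own, with the rest of the molecule held the same: the step is a number 9 percentage points lower from compound 1 to compound 4 (within the scatter) and shows no change beyond the usual scatter. Within the data shown here, until now the only hint came from compound 2, whose core differs, so it said nothing direct about this position. Here a ring of four carbons enters where a single carbon stood, and this one pair shows that the swap is tolerated in this test, though it sets no general rule.

From the compounds shown here alone, whether a longer chain such as butyl, or a chain carrying an amine, on the same nitrogen would also stay within the scatter of compound 1 remains open. Nothing measured here explains the result or shows which part of these molecules decides how much of them remains.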